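The compounds below may be only part of what the source reports. "The series", "measured", "known", "first", "only" and "open" are said of these compounds alone.

Of the compounds shown here, three that share one core have been tested in an assay for inhibition of Dihydrofolate reductase (Gallus gallus); on this read-out higher numbers stand for weaker inhibition and lower numbers for stronger inhibition. Compound 1 `C=CCOc1ccccc1Cc1cnc(N)nc1N` gives 21400 nM. Compound 2 `COc1ccccc1Cc1cnc(N)nc1N` gives 28800 nM, and compound 3 `NC(=O)COc1ccccc1Cc1cnc(N)nc1N` gives 33900 nM. Among these three numbers compound 2 holds the second highest, with compound 3 nearest and compound 1 furthest, and all of its steps to the others lie within the scatter: a 1.3-fold higher number from compound 1 to compound 2 (0.13 log units; within the scatter), a 1.2-fold higher number from compound 2 to compound 3 (0.07 log units; within the scatter), and between the two outer compounds a 1.6-fold higher number from compound 1 to compound 3 (0.20 log units; within the scatter). Compound 4 `Nc1ncc(Cc2ccccc2Cl)c(N)n1` has not yet been measured. It differs from compound 2 in one place: chloro in place of methoxy on an aromatic carbon. The three measured steps all changed only what hangs on the oxygen of the methoxy group; none of them removes that oxygen or puts chloro in its place, so they bear on the new step only loosely. Since every change made so far stayed within the scatter, a step from compound 2 to compound 4 that also stays within the scatter is expected, estimated as a 1.2-fold lower number from compound 2 to compound 4 (0.06 log units; within the scatter). For compound 4 the expected inhibition constant is 25000 nM, with a range from 8000 nM to 80000 nM.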

Compound 4, inhibition constant: 17400 nM
Compound 4: the middle estimate sits 1.4-fold (0.16 log units) above what was measured; the measured number falls inside the stated range.
By their numbers in this assay, from the lowest: compounds 4, 1, 2 and 3 (each within the scatter of the next).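

Among these compounds, compound 4 is the first change that removes the oxygen from this aromatic carbon instead of altering what hangs on it, and chloro in place of methoxy gives a 1.7-fold lower number from compound 2 to compound 4 (0.22 log units; within the scatter) as its step. The larger groups behave alike, with chloro in place of carbamoylmethoxy giving a 1.9-fold lower number from compound 3 to compound 4 (0.29 log units; within the scatter) and chloro in place of allyloxy giving a 1.2-fold lower number from compound 1 to compound 4 (0.09 log units; within the scatter), so the four groups shown here all sit within the scatter of one another and this carbon does not need the oxygen to keep that level. Nothing measured here offers a reason for this flat picture.

Going by these compounds, it remains open whether any group at this carbon can move the number beyond the scatter, for example an amine, a carboxylic acid or a longer chain. Whether chloro would behave the same on another carbon of the ring also stays unanswered.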